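The source may report more compounds than this note shows. Statements on the series, on what has been measured and on what is new or still open speak of the compounds shown alone.

Measured so far, in a functional assay (strain AB) with Danio rerio as the target, read by microscopy, with a stated time of 1 h; on this read-out higher numbers stand for an effect only at larger amounts of compound and lower numbers for an effect already at smaller amounts:
- Compound 1 `CCN1CCc2c(sc(NC(=S)Nc3ccc(Cl)cc3)c2C(N)=O)C1`: 6570 nM
- Compound 2 `CN1CCc2c(sc(NC(=O)Nc3ccc(Cl)cc3)c2C(N)=O)C1`: 4700 nM
- Compound 3 `NC(=O)c1c(NC(=O)Nc2ccc(Cl)cc2)sc2c1CCN(CCCNC(=O)CCc1cccc3ccccc13)C2`: 110 nM

Compound 3 has the lowest number of the three, so it acts at the smallest amount of compound in this assay. Its gaps to compound 2 and compound 1 both lie beyond the usual scatter of repeated measurements. The values of compound 1 and compound 2 lie within that scatter of each other. Compound 3 is also the only one of the three that carries a long chain ending in an aromatic group.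

The next compound is compound 4 `NC(=O)c1c(NC(=O)Nc2ccc(Cl)cc2)sc2c1CCN(CCCNC(=O)CCc1c[nH]c3ccccc13)C2`. It has 1H-indol-3-yl in place of naphthalen-1-yl on a saturated chain carbon, two bonds along the chain from a carbonyl carbon. The rest of the structure stays the same.

Among the measured compounds shown here, no measured pair shows this kind of swap, so the expectation rests on a single compound. The long chain stays in place, and compound 3 with it reaches 110 nM, so compound 4 is expected to stay close to that value, with no step beyond the scatter. The expected change is a 1.8-fold higher number from compound 3 to compound 4 (0.26 log units; within the scatter). The estimate for compound 4 is 200 nM, with an expected range of 60 nM to 650 nM.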

Compound 4, half-maximal effective concentration: 100 nM
For compound 4 the middle estimate is 2.0-fold (0.30 log units) above the measured one, within the range that was stated.
By their numbers in this assay, from the lowest: compounds 4 and 3 (each within the scatter of the next); then compounds 2 and 1 (each within the scatter of the next).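

In this assay, placing 1H-indol-3-yl where naphthalen-1-yl stood, on a saturated chain carbon two bonds along the chain from a carbonyl carbon, gives a 1.1-fold lower number from compound 3 to compound 4 (0.04 log units; within the scatter), so the read-out does not tell these two compounds apart. Compound 3 alone could not show whether its value depended on naphthalen-1-yl in particular; this pair shows that the group can be replaced without a step beyond the scatter, even though the new group has a five-membered aromatic ring with a hetero atom and a hydrogen-bond donor, which naphthalen-1-yl lacks. No measured evidence here offers a reason for this outcome.

The compounds shown leave open how a simple phenyl ring, a cyclohexyl group or a carboxylic acid would behave at this place, and so whether an aromatic group is needed there at all. They also leave open how a longer chain carrying the same 1H-indol-3-yl group would compare with compound 4.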